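Thiazolyl for phenyl on the piperazine of an oxime ether series

The compounds below may be only part of what the source reports. "The series", "measured", "known", "first", "only" and "open" are said of these compounds alone.

Compound 1 `O/N=C(\CCN1CCN(c2ccccn2)CC1)c1ccc(F)cc1F`: 8.9 nM
Compound 2 `CC(C)O/N=C(\CCN1CCN(c2ccccn2)CC1)c1ccccc1`: 164 nM
Compound 3 `CCO/N=C(\CCN1CCN(c2ccccc2)CC1)c1ccccc1`: 109 nM

The measurements come from a functional assay on HEK293 cells with D(4) dopamine receptor (Homo sapiens) as the target, read by FLIPR; on this read-out higher numbers stand for an effect only at larger amounts of compound and lower numbers for an effect already at smaller amounts. Among the three numbers, compound 3 stands second highest. Its nearest neighbour is compound 2, whose number lies within the scatter of that of compound 3, so no order between the two can be read. Compound 1 stands furthest from compound 3, with a lower number that lies beyond the scatter; compound 1 differs from compound 3 in more than one place, so its distance cannot be tied to a single change.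

Compound 4 `CCO/N=C(\CCN1CCN(c2nccs2)CC1)c1ccccc1` is not yet measured. It differs from compound 3 in one place: 1,3-thiazol-2-yl in place of phenyl on an amine nitrogen in a ring.

Among the measured compounds shown here, no measured pair shows this change, so its direction is open. The account rests only on the three numbers above. The expected step of a 1.4-fold lower number from compound 3 to compound 4 (0.13 log units; within the scatter) is estimated as small, within the scatter or only slightly beyond it, with no clear direction. Compound 4 is therefore expected to give about 80 nM, within a range from 25 nM to 250 nM.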

Compound 4, half-maximal effective concentration: 81.8 nM
Estimate against measurement, compound 4: 1.0-fold (0.01 log units) below; the range from low to high includes it.
By their numbers in this assay, from the lowest: compound 1; then compounds 4, 3 and 2 (each within the scatter of the next).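

In this assay, placing 1,3-thiazol-2-yl on the amine nitrogen in a ring in place of phenyl gives a 1.3-fold lower number from compound 3 to compound 4 (0.12 log units; within the scatter) and is the first one-place step among these compounds. It shows that, in the core of compound 3, a five-membered aromatic ring with 2 hetero atoms can stand at this position in place of a six-membered aromatic ring of carbon only without a step beyond the scatter. No measurement at hand accounts for this outcome.

This single pair does not show whether the same change would give a similar step on the core of compound 1 or compound 2. It also leaves open whether a pyrimidin-2-yl ring at this position, or an amine or a carboxylic acid on the thiazole ring, would move the number beyond the scatter.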